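The source may report more compounds than this note shows. Statements on the series, on what has been measured and on what is new or still open speak of the compounds shown alone.

Compound 1 `Cc1nnc(SCC(=O)Nc2ccc(-c3nc(-c4ccccc4)c(-c4ccccc4)n3C)cc2)s1` gives 90.5% in a functional assay on HT-29 cells (Homo sapiens) for cytotoxicity, read by MTT assay, with a stated time of 24 h, tested at 80 ug/mL; on this read-out lower numbers stand for a weaker effect and higher numbers for a stronger effect at the one concentration tested. Compound 2 `CN1CCN(CC(=O)Nc2ccc(-c3nc(-c4ccccc4)c(-c4ccccc4)n3C)cc2)CC1` gives 53.1% in this assay and so stands lowest of the two numbers measured. Within the data shown here, the only measured step, a number 37.4 percentage points lower from compound 1 to compound 2 (beyond the scatter), is large but concerns a different part of the shared core. Compound 3 `Cn1c(-c2ccc(NC(=O)CN3CCN(c4ccccc4)CC3)cc2)nc(-c2ccccc2)c1-c1ccccc1` differs from compound 2 by phenyl in place of methyl on an amine nitrogen in a ring. Among the measured compounds shown here, no measured step bears on this change, so no shift beyond the scatter is expected in this assay, with wide uncertainty either way. Compound 3 is expected at 58%, ranging from 32% to 84%. The expected step is a number 4.9 percentage points higher from compound 2 to compound 3 (within the scatter).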

Compound 3, a percentage reported as activity, at one concentration (the size of the read-out at that concentration, not a potency): 63.7%
Beside the measured number, compound 3's estimate is 5.7 percentage points below it; low and high end bracket the measured number.
By their numbers in this assay, from the lowest: compound 2; then compound 3; then compound 1.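

On the amine nitrogen in the ring, phenyl in place of methyl gives a number 10.6 percentage points higher from compound 2 to compound 3 (beyond the scatter) in this assay, so this position responds to the change, though only modestly. The swap from (5-methyl-1,3,4-thiadiazol-2-yl)sulfanyl to 4-phenylpiperazin-1-yl still gives a number 26.8 percentage points lower from compound 1 to compound 3 (beyond the scatter), so phenyl recovers only part of the gap. Nothing available explains either step.

Open, as far as these compounds go, is whether benzyl or a bare hydrogen on this nitrogen would follow phenyl or methyl. Also open, from the compounds shown here alone, is whether a chlorine or methoxy group on the new phenyl would shift the read-out further.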